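The source may hold more compounds than are shown below. What is called first, only, known or untested is meant among the compounds shown, and "the series" means these compounds.

Within the data shown here, the study measured two compounds so far and leaves a third to be tested. Compound 1 `CC1(C)CCC[C@]1(C)c1ccc(C=O)cc1` and compound 2 `C=C1CCC[C@]2(C)CCC(c3cn(-c4ccc(OC)cc4)nn3)=CC[C@@]12C` share no single-point relation, so only their two values can be set side by side. In a functional assay on B16 cells (Mus musculus) for cytotoxicity, read by MTT assay, with a stated time of 48 h (on this read-out higher numbers stand for weaker inhibition and lower numbers for stronger inhibition), compound 1 gives 257000 nM. In this assay compound 2 gives 209000 nM, and this number lies within the usual scatter of the one for compound 1, so on the two numbers shown compound 2 stands level with compound 1 rather than apart from it; both sit in a range of weak inhibition.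

Compound 3 `C=C1CCC[C@]2(C)CCC(c3cn(-c4ccc(Cl)cc4)nn3)=CC[C@@]12C` is built on the same core as compound 2 and differs from it in one place: chloro in place of methoxy on an aromatic carbon. Among the measured compounds shown here, no step between two measured compounds is known here, so there is no directly comparable change to lean on. Given that compound 2 gives 209000 nM, the step is expected to stay within the scatter in either direction, amounting to a 1.2-fold lower number from compound 2 to compound 3 (0.06 log units; within the scatter). Compound 3 is therefore estimated at 180000 nM, with a range from 70000 nM to 450000 nM.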

Compound 3, half-maximal inhibitory concentration: 27200 nM
Estimate against measurement, compound 3: 6.6-fold (0.82 log units) above; measured number outside the range, below it.
By their numbers in this assay, from the lowest: compound 3; then compounds 2 and 1 (each within the scatter of the next).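

Until now, compound 1 and compound 2 could only be set side by side, and neither number said anything about a single position on either structure. Among these compounds, the change from 4-methoxyphenyl to 4-chlorophenyl now gives a first reading of one place, the aromatic carbon para to a large group: in this assay chloro in place of methoxy gives a 7.7-fold lower number from compound 2 to compound 3 (0.89 log units; beyond the scatter) and lies beyond the scatter, so what sits at this place on the shared core does matter to the read-out, even though the numbers remain high. Nothing at hand says why the number moves with this change, and the finding rests on this one pair alone.

The compounds shown leave open whether a bromo, a trifluoromethyl or an amine at the same place would follow chloro or stay level with methoxy, and what the ring gives with a plain hydrogen there. They also leave open whether the same exchange would move the number in the same direction on a different core.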